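Aryl swap on the ring nitrogen: compound 3 to compound 4

The source may report more compounds than this note shows. Statements on the series, on what has been measured and on what is new or still open speak of the compounds shown alone.

Measured so far:
compound 1 `Cc1cccc(-n2nncc2CN2C(=O)C3(C(C#N)=C(N)Oc4c3c3nc5ccccc5nc3c3ccccc43)c3ccccc32)c1`
compound 2 `Cc1ccc(-n2nncc2CN2C(=O)C3(C(C#N)=C(N)Oc4c3c3nc5ccccc5nc3c3ccccc43)c3ccccc32)cc1Cl`
compound 3 `COc1ccccc1-n1nncc1CN1C(=O)C2(C(C#N)=C(N)Oc3c(N)cc4nc5ccccc5nc4c32)c2ccccc21`

In a functional assay on HCT-116 cells (Homo sapiens) for antiproliferative activity, read by MTT assay, with a stated time of 48 h (a lower number here means a stronger inhibitor, a higher number a weaker inhibitor), compound 1 gives only a limit, > 50000 nM. Compound 2 likewise reaches only a limit in this assay, > 50000 nM. Compound 3 also stops at a limit in this assay, > 50000 nM. Within the data shown here, the single step between measured compounds, a step that the two limits leave unreadable from compound 1 to compound 2, is therefore unreadable; every value in the set sits at the limit of > 50000 nM in this assay, at which 3 of the 3 values shown sit.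

Compound 4 `N#CC1=C(N)Oc2c(N)cc3nc4ccccc4nc3c2C12C(=O)N(Cc1cnnn1-c1ccc([N+](=O)[O-])cc1[N+](=O)[O-])c1ccccc12` differs from compound 3 by 2,4-dinitrophenyl in place of 2-methoxyphenyl on an aromatic nitrogen. Among the measured compounds shown here, no measured step touches this change, and with all three values at a limit, neither size nor direction can be read from them. The expectation for compound 4 is that it stays at the same limit: an estimated 50000 nM, range 20000 nM to 200000 nM, meaning an expected step of a number no higher from compound 3 to compound 4 (the limit leaves the size open).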

Compound 4, half-maximal inhibitory concentration: 23900 nM
The estimate for compound 4 lay 2.1-fold (0.32 log units) above the measured number, and the stated range covers the measured number.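

In this assay, among these compounds, 2,4-dinitrophenyl in place of 2-methoxyphenyl on the aromatic nitrogen gives the first readable step: an at least 2.0-fold lower number from compound 3 to compound 4 (0.32 log units; beyond the scatter). This shows that, on the shared core of compound 3, the aryl group at this position can move the number off the limit, which the unreadable step between the two earlier limits could not show. The other values remain limits: the limit of > 50000 nM in this assay, at which 3 of the 4 values shown sit.

From the compounds shown here alone, whether a single nitro group would give the same step stays open. So does the outcome with an amine or a carboxylic acid on this phenyl ring, or with 2,4-dinitrophenyl on the core of compound 1.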